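Aminomethyl to hydroxymethyl on the shared core

A few compounds are considered here, and "the series" means these few. Any claim that something is new, unique, unknown or untested is made for them only; others in the source may bear on it.

Of the compounds shown here, three have numbers so far in an ADME assay on HEp-2 cells (Homo sapiens) for cytotoxicity; a higher number here means that more compound is tolerated, a lower number that less compound is tolerated. Compound 1 (`CNCc1ccc2c(c1)nc(Cn1c(=O)n(C(C)C)c3ccccc31)n2CCC(C)C`) gives 1480 nM, compound 2 (`CC(C)CCn1c(Cn2c(=O)n(C(C)C)c3ccccc32)nc2ccc(C#N)cc21`) gives 10000 nM, and compound 3 (`CC(C)CCn1c(Cn2c(=O)n(C(C)C)c3ccccc32)nc2ccc(CN)cc21`) gives 28100 nM. Compound 3 therefore holds the highest number of the three, with compound 2 nearest to it and compound 1 furthest away, both gaps beyond the scatter.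

The next compound is compound 4 (`CC(C)CCn1c(Cn2c(=O)n(C(C)C)c3ccccc32)nc2ccc(CO)cc21`), with hydroxy in place of amino on a saturated chain carbon bound to an aromatic carbon, which turns aminomethyl into hydroxymethyl: hydroxy in place of amino on a saturated chain carbon bound to an aromatic carbon.

Going by the values given here, one measured step bears directly on this group: a 2.8-fold higher number from compound 2 to compound 3 (0.45 log units; beyond the scatter), a modest step that introduced the aminomethyl now being changed. Among the compounds with values here, no measured step links compound 1 directly to this change, so it serves only as the low end of the numbers seen in this assay. Within the data shown here, no hydroxymethyl compound has been measured, so the direction remains uncertain. Among the measured compounds shown here, a modest move is expected, no larger than the one step measured at this group, and slightly more likely downward. The expected step is a 1.6-fold lower number from compound 3 to compound 4 (0.19 log units; within the scatter). For compound 4 the estimated value is 18000 nM, with an expected range of 7000 nM to 45000 nM.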

Compound 4, half-maximal cytotoxic concentration: 81600 nM
Beside the measured number, compound 4's estimate is 4.5-fold (0.66 log units) below it; measured number above the stated range.
By their numbers in this assay, from the lowest: compound 1; then compound 2; then compound 3; then compound 4.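

Replacing amino with hydroxy at this position, on a saturated chain carbon bound to an aromatic carbon, gives in this assay a 2.9-fold higher number from compound 3 to compound 4 (0.46 log units; beyond the scatter) and is not a neutral exchange, although the heavy-atom count stays the same and no net charge enters or leaves. The aminomethyl of compound 3 therefore does not mark the top of the numbers at this position, and the hydroxymethyl extends the rise that a 2.8-fold higher number from compound 2 to compound 3 (0.45 log units; beyond the scatter) first showed. Measured against the nitrile, the new group gives an 8.2-fold higher number from compound 2 to compound 4 (0.91 log units; beyond the scatter) and is the largest single-place step in this assay among these compounds, with both replacements of cyano moving the number in the same direction. No supporting data on these compounds explain the difference between amino and hydroxy.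

Open, from the compounds shown here alone, is whether a methoxymethyl, a carboxylic acid or a longer hydroxyalkyl chain at this position would raise the number further or lower it. Also open, going by these compounds, is whether the amino-to-hydroxy gain in this assay would recur with a different group elsewhere on the shared core.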